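Swapping a silicon-bearing group for dimethylcarbamoyl

The source may hold more compounds than are shown below. What is called first, only, known or untested is meant among the compounds shown, and "the series" means these compounds.

In a functional assay on HL-60 cells (Homo sapiens) for antiproliferative activity, read by MTT assay, with a stated time of 48 h (on this read-out higher numbers stand for weaker inhibition and lower numbers for stronger inhibition), on a shared core, compound 1 `COC/C1=C/C[C@](C)(CCC=C(C)C)/C=C/[C@@H](OC(=O)C=C(C)C)[C@](C)(O)/C=C/C1=O` gives 3070 nM and compound 2 `CC(C)=CCC[C@]1(C)/C=C/[C@@H](OC(=O)C=C(C)C)[C@](C)(O)/C=C/C(=O)/C(CCl)=C\C1` gives 160 nM while compound 3 `CC[Si](CC)(CC)C/C1=C/C[C@](C)(CCC=C(C)C)/C=C/[C@@H](OC(=O)C=C(C)C)[C@](C)(O)/C=C/C1=O` gives 2810 nM as its reading. Compound 3 therefore sits level with compound 1, and both stand far from compound 2.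

Moving to compound 4 `CC(C)=CCC[C@]1(C)/C=C/[C@@H](OC(=O)C=C(C)C)[C@](C)(O)/C=C/C(=O)/C(C(=O)N(C)C)=C\C1` alters one place on a double-bonded ring carbon: a group of 5 heavy atoms (3 carbon, 1 nitrogen, 1 oxygen; no ring) in place of a group of 8 heavy atoms (7 carbon, 1 silicon; no ring), on a double-bonded ring carbon is the whole difference.

Within the data shown here, three measured steps bear on this, all made on a saturated chain carbon bound to a double-bonded ring carbon. Of these, a 1.1-fold lower number from compound 1 to compound 3 (0.04 log units; within the scatter) shows two very different groups reading alike, whereas a 19-fold lower number from compound 1 to compound 2 (1.28 log units; beyond the scatter) and an 18-fold higher number from compound 2 to compound 3 (1.24 log units; beyond the scatter) both set the chlorine-bearing compound 2 apart. Compound 4 carries no chlorine, and its new group stands on the ring carbon itself, so these steps are only a loose guide. The expected result is a 1.1-fold lower number from compound 3 to compound 4 (0.05 log units; within the scatter) in this assay with no large move in either direction. Compound 4 is estimated at 2500 nM with a likely range from 600 nM to 10000 nM overall.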

Compound 4, half-maximal inhibitory concentration: 3340 nM
Compound 4: middle estimate off by 1.3-fold (0.13 log units), on the low side; the range from low to high includes it.
By their numbers in this assay, from the lowest: compound 2; then compounds 3, 1 and 4 (each within the scatter of the next).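

In this assay, dimethylcarbamoyl on the double-bonded ring carbon reads level with the silicon-bearing group (a 1.2-fold higher number from compound 3 to compound 4 (0.08 log units; within the scatter)) and with methoxymethyl (a 1.1-fold higher number from compound 1 to compound 4 (0.04 log units; within the scatter)), so three groups made of quite different atoms cannot be told apart at this position. Chloromethyl remains the only group shown to stand apart, and the new amide widens that picture without changing it (a 21-fold higher number from compound 2 to compound 4 (1.32 log units; beyond the scatter)): among these four compounds, compound 2 alone gives the lower number. No measurement shown explains why chloromethyl differs from the other three groups.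

As far as these compounds go, it remains open whether bromomethyl or fluoromethyl would read like chloromethyl or like the other three groups. From the compounds shown here alone, the readings of an aminomethyl group or a carboxylic acid on this ring carbon also remain unknown.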